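A Chloro Swap Among Low Unbound Fractions

This account rests on a few compounds, and the source may have more. Where it says the series, first, only, none or still open, it means among the compounds named here.

Of the compounds shown here, three built on one shared core have been measured in an ADME assay on a cell-free system (plasma, Homo sapiens) for protein binding; a higher number here means a larger unbound share of the compound, a lower number a smaller unbound share. There, compound 1 `Cc1c(C(F)F)nnc2sc(C(=O)NC3CN(c4ncc(C(F)(F)F)cn4)C3)c(N)c12` gives 0.02, compound 2 `Cc1c(CF)nnc2sc(C(=O)NC3CN(c4ncc(C(F)(F)F)cn4)C3)c(N)c12` gives 0.042, and compound 3 `COc1nnc2sc(C(=O)NC3CN(c4ncc(C(F)(F)F)cn4)C3)c(N)c2c1C` gives 0.02. Compound 3 therefore stands level with compound 1, and together they hold the lowest number of the three.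

Compound 4 `Cc1c(Cl)nnc2sc(C(=O)NC3CN(c4ncc(C(F)(F)F)cn4)C3)c(N)c12` has not yet been measured. It differs from compound 3 by chloro in place of methoxy on an aromatic carbon. Going by the values given here, no measured step makes this exact exchange, so the evidence is indirect. Two measured steps bring in the same methoxy group. Methoxy in place of difluoromethyl gave no change at the digits printed from compound 1 to compound 3 (within the scatter), and methoxy in place of fluoromethyl gave a 2.1-fold lower number from compound 2 to compound 3 (0.32 log units; beyond the scatter). The remaining step, hydrogen in place of fluoro, gave a 2.1-fold higher number from compound 1 to compound 2 (0.32 log units; beyond the scatter). None of these exchanges moved the number by more than a modest amount, so only a small change is expected here, in a slightly upward direction and not beyond the scatter. In this assay the expected step is a 1.3-fold higher number from compound 3 to compound 4 (0.10 log units; within the scatter). Compound 4 is estimated at 0.025, with an expected range from 0.012 to 0.05.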

Compound 4, unbound fraction: 0.022
Compound 4: middle estimate off by 1.1-fold (0.06 log units), on the high side; the range from low to high includes it.
By their numbers in this assay, from the lowest: compounds 1, 3, 4 and 2 (each within the scatter of the next, the first and the last beyond it).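

In this assay, the position next to the ring nitrogen now carries a fourth group, and chloro, with one heavy atom and no hydrogen-bond acceptor, reads alike with methoxy (a 1.1-fold higher number from compound 3 to compound 4 (0.04 log units; within the scatter)) and with difluoromethyl (a 1.1-fold higher number from compound 1 to compound 4 (0.04 log units; within the scatter)). Compound 4 also stands apart from the fluoromethyl compound less clearly than compounds 1 and 3 do, since its step is within the scatter (a 1.9-fold lower number from compound 2 to compound 4 (0.28 log units; within the scatter)), whereas the steps to compound 2 from those two compounds lie beyond it. The earlier compounds shown here could not show that this position accepts a single chlorine atom in place of the two heavy atoms of methoxy and its hydrogen-bond acceptor without a change that can be told from the scatter, and compound 2 remains the only one set apart from any other. Nothing shown here gives a reason for these readings.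

Going by these compounds, whether an amine, a carboxylic acid or a longer chain at this position would leave the unbound fraction in the same narrow band remains open. So does whether the exchange of methoxy for chloro would read the same with other groups elsewhere on the shared core.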